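A few compounds are considered here, and "the series" means these few. Any claim that something is new, unique, unknown or untested is made for them only; others in the source may bear on it.

Going by the values given here, in an ADME assay on microsomes from liver (Homo sapiens) for metabolic stability, with a stated time of 10 min (on this read-out lower numbers stand for a less stable compound and higher numbers for a more stable compound), compound 1 `FC(F)(F)c1ccccc1-c1ccc2[nH]c(C3=NOC4(CCCCC4)C3)nc2c1` gives 100% and stands highest of the two numbers so far, above compound 2 `Fc1cccc(C(F)(F)F)c1-c1ccc2[nH]c(C3=NOC4(CCCCC4)C3)nc2c1` at 38% with fluoro in place of hydrogen on an aromatic carbon. Among the compounds with values here, compound 3 `CC(C)(O)c1ccccc1-c1ccc2[nH]c(C3=NOC4(CCCCC4)C3)nc2c1` carries 1-hydroxy-1-methylethyl in place of trifluoromethyl on an aromatic carbon and no measured step tests this change. Within the data shown here, the only step is a number 62 percentage points lower from compound 1 to compound 2 (beyond the scatter) and it is large, so it bears only loosely, showing that one small edit can move this read-out far. The expected step is a number 30 percentage points lower from compound 1 to compound 3 (beyond the scatter) and it is a moderate fall. For compound 3 the estimated value is 70% with an expected range (35% to 100%).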

Compound 3, percent of the compound remaining: 44%
The estimate for compound 3 lay 26 percentage points above the measured number; low and high end bracket the measured number.
By their numbers in this assay, from the lowest: compounds 2 and 3 (each within the scatter of the next); then compound 1.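

In this assay, exchanging trifluoromethyl for 1-hydroxy-1-methylethyl gives a number 56 percentage points lower from compound 1 to compound 3 (beyond the scatter), a large fall. The earlier step changed only a ring hydrogen; this one shows that the group at this place, on an aromatic carbon and ortho to a large group, also matters, even with the same count of heavy atoms entering as leaving. Nothing at hand accounts for the fall. From the compounds shown here alone, whether a methoxy group, an amine or a carboxylic acid at this place would stay near compound 1 at 100% remains open.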